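Sulfonyl aryl swap on a benzoxazole sulfonamide scaffold

The source may hold more compounds than are shown below. What is called first, only, known or untested is meant among the compounds shown, and "the series" means these compounds.

Two compounds share a core in which a sulfonamide nitrogen carries a benzoxazole-bearing aryl group, and they differ only in the ring on the sulfonyl sulfur. Compound 1 `O=S(=O)(Nc1ccc(-c2nc3ccccc3o2)cc1)c1cccc(F)c1` carries a 3-fluorophenyl there, and in an assay on cells for inhibition of HSP60/HSP10 (Homo sapiens), with a stated time of 60 min (on this read-out lower numbers stand for stronger inhibition and higher numbers for weaker inhibition), compound 1 gives 71000 nM. Compound 2 `O=S(=O)(Nc1ccc(-c2nc3ccccc3o2)cc1)c1cccs1` carries a thiophen-2-yl instead, and in this assay compound 2 gives 63000 nM. Within the data shown here, the only measured step, a 1.1-fold lower number from compound 1 to compound 2 (0.05 log units; within the scatter), is within the scatter, so the two compounds cannot be ordered against each other on these numbers.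

Compound 3 `COc1ccc(S(=O)(=O)Nc2ccc(-c3nc4ccccc4o3)cc2)cc1` is the next variation at the same position: 4-methoxyphenyl in place of thiophen-2-yl on a sulfonyl sulfur. Among the measured compounds shown here, the one step that bears on it, a 1.1-fold lower number from compound 1 to compound 2 (0.05 log units; within the scatter), shows that exchanging the ring on the sulfonyl sulfur left this assay essentially unchanged between compound 1 and compound 2. On that basis the step to compound 3 is expected to stay within the scatter as well, a 1.1-fold lower number from compound 2 to compound 3 (0.02 log units; within the scatter). Compound 3 is therefore estimated at 60000 nM in this assay, with a range from 25000 nM to 150000 nM.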

Compound 3, half-maximal inhibitory concentration: > 100000 nM
Compound 3 ended at the assay's limit; the forecaster's own chance of this, stated with the estimate: 15%; middle value at least 1.6-fold (0.22 log units) away from the limit.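

Compound 3 gives > 100000 nM in this assay, and this is a limit of the assay, not a number. Its steps therefore give only floors, an at least 1.5-fold higher number from compound 2 to compound 3 (0.20 log units; that floor lies within the scatter) and an at least 1.4-fold higher number from compound 1 to compound 3 (0.14 log units; that floor lies within the scatter), so the 4-methoxyphenyl on the sulfonyl sulfur cannot yet be told apart from the other two rings, yet it can no longer be assumed to match them as compound 1 and compound 2 matched each other. What is new is that this position now holds a ring whose true distance from the others stays hidden, leaving the flat picture from the first pair untested for this change, and compound 3 alone meets that ceiling: the limit of > 100000 nM in this assay, at which 1 of the 3 values shown sits.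

The compounds shown leave open whether the result for compound 3 belongs to the methoxy group or to the phenyl ring that carries it, a question an unsubstituted phenyl or a 4-hydroxyphenyl on the sulfonyl sulfur would address. They also leave open whether any ring at this position, such as a pyridine or a 4-aminophenyl, would give a clearly lower number than the first two compounds.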